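The source may report more compounds than this note shows. Statements on the series, on what has been measured and on what is new or still open speak of the compounds shown alone.

Measured so far in a functional assay on NCI-H460 cells (Homo sapiens) for inhibition, read by MTT assay, with a stated time of 24 h, tested at 100 ug/mL; on this read-out lower numbers stand for less inhibition of growth and higher numbers for more inhibition of growth at the one concentration tested:
compound 1 `CC(=O)SCCC(CCCCC(=O)O)SC(C)=O` gives 11%
compound 2 `O=C(CCCCC1CCSS1)Nc1ccc(Br)cn1` gives 52%
compound 3 `O=C(CCCCC(S)CCS)Nc1ccc(Cl)cc1` gives 40.9%

Compound 3 at 40.9% is the second highest of these three numbers, with compound 2 higher and compound 1 lower, both gaps beyond the scatter. Next comes compound 4 `COc1ccc(NC(=O)CCCCC(S)CCS)cc1`, which keeps the rest of compound 3 and carries methoxy in place of chloro on an aromatic carbon, para to a large group (methoxy in place of chloro on an aromatic carbon). Going by the values given here, no measured pair differs in one place only, so the data give no direct size for this change. In this assay no step beyond the scatter is expected, with a slight downward drift as the likelier direction. The expectation rests on compound 3 at 40.9% as the only close reference. The expected a number 2.9 percentage points lower from compound 3 to compound 4 (within the scatter) is small and is an estimate only. Compound 4 is estimated at 38% within an expected range from 24% to 52% on this read-out.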

Compound 4, percent growth inhibition at one concentration: 23.5%
Estimate against measurement, compound 4: 14.5 percentage points above; measured number outside the range, below it.
By their numbers in this assay, from the lowest: compound 1; then compound 4; then compound 3; then compound 2.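

In this assay, the aromatic carbon para to a large group now has its first one-place comparison: methoxy in place of chloro gives a number 17.4 percentage points lower from compound 3 to compound 4 (beyond the scatter), so the number responds to the group held at this position. This is a single pair with the rest of compound 3 kept, and it shows only that chloro gives the higher number of these two groups on this core, not a trend across substituents. Nothing measured here accounts for the step.

On these data alone, whether an amine, a nitrile or a hydroxyl on the same aromatic carbon would stand nearer to chloro or to methoxy remains open. Also open, as far as these compounds go, is whether the same exchange would give a step of similar size on the core of compound 2.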